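Biphenyl extension of a thioether citrate-type inhibitor

The source may report more compounds than this note shows. Statements on the series, on what has been measured and on what is new or still open speak of the compounds shown alone.

For the measured compounds named here, compound 2 `O=C(O)CC(O)(CSCCCCCc1ccccc1)C(=O)O` gives 490000 nM in an assay on isolated protein for inhibition of ATP-citrate synthase (Rattus norvegicus) (on this read-out higher numbers stand for weaker inhibition and lower numbers for stronger inhibition), the highest of the two numbers measured so far. Its nearest neighbour is compound 1 `O=C(O)CC(O)(CSCCCCCCc1ccccc1Cl)C(=O)O`, which gives 69000 nM; the step from compound 1 to compound 2 was a 7.1-fold higher number from compound 1 to compound 2 (0.85 log units; beyond the scatter), a modest change beyond the scatter. Compound 3 `O=C(O)CC(O)(CSCCCCCc1ccc(-c2ccccc2)cc1)C(=O)O` differs from compound 2 by phenyl in place of hydrogen on an aromatic carbon, placed on an aromatic carbon of a six-membered aromatic ring of carbon only, para to a large group. Going by the values given here, only that one step bears on the new change, and it shows that a larger terminal aromatic group was paired with a lower number. On that basis an estimated step of a 4.1-fold lower number from compound 2 to compound 3 (0.61 log units; beyond the scatter) is expected for compound 3 in this assay, in the direction of stronger inhibition, though the evidence is thin. Compound 3 is therefore estimated at 120000 nM, within a range from 25000 nM to 500000 nM.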

Compound 3, inhibition constant: 226000 nM
The estimate for compound 3 lay 1.9-fold (0.27 log units) below the measured number; measured number inside the range.
By their numbers in this assay, from the lowest: compound 1; then compound 3; then compound 2.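

In this assay, phenyl in place of hydrogen on an aromatic carbon, para to a large group, gave a 2.2-fold lower number from compound 2 to compound 3 (0.34 log units; beyond the scatter), a modest move towards stronger inhibition. The earlier step changed the group on the saturated chain, whereas this one is the first change shown on the aromatic ring itself, and it shows that this ring position takes an added phenyl without any loss of inhibition. Nothing among the data shown accounts for this step.

The compounds shown leave open how a chlorine, a methoxy group or a carboxylic acid on the same aromatic carbon would compare with phenyl. They also leave open whether the added phenyl would give a step of similar size on a longer chain.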